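The source may hold more compounds than are shown below. What is called first, only, known or untested is meant among the compounds shown, and "the series" means these compounds.

Working notes on the series. The shared core carries a furan-2-yl group in compound 1 `CC(C)N(Cc1cccc(OCCCCCC(=O)O)c1)C(=O)c1ccc(-c2ccco2)cc1`; compound 2 `CC(C)N(Cc1cccc(OCCCCCC(=O)O)c1)C(=O)c1ccc(-c2cc3ccccc3n2S(=O)(=O)c2ccccc2)cc1` is the other measured member, and compound 3 `CC(C)N(Cc1cccc(OCCCCCC(=O)O)c1)C(=O)c1ccc(-c2c[nH]c3ccccc23)cc1` is the one still to be measured. In an ADME assay on BJ cells (Homo sapiens) for cytotoxicity, read by CellTiter-Glo and resazurin assay, with a stated time of 72 h (on this read-out higher numbers stand for an effect only at larger amounts of compound and lower numbers for an effect already at smaller amounts), compound 1 gives > 26000 nM, which is a limit of the assay and not a number. In this assay compound 2 gives > 26000 nM, again a limit rather than a number. For the measured compounds named here, compound 1 therefore stands at the limit of this assay alongside the only other measured compound, since (the limit of > 26000 nM in this assay, at which 2 of the 2 values shown sit). Going by the values given here, no step between two measured compounds can be counted here, so no measured size of effect is available to lean on. Compound 3 differs from compound 1 by 1H-indol-3-yl in place of furan-2-yl on an aromatic carbon. For this change the step in this assay is expected to be none beyond the scatter, with a step that the limit leaves unreadable from compound 1 to compound 3 as the estimated step, the read-out most likely coming back once more only as a limit. Compound 3 is expected to give about 30000 nM in this assay, within a range from 10000 nM to 100000 nM.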

Compound 3, half-maximal effective concentration: > 26000 nM
Compound 3: a limit, no number (the forecaster's own chance of this, stated with the estimate: 80%); the middle value is on the limit's open side.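

Compound 3 also comes back as a limit and not a number, so the step from compound 1 to compound 3 in this assay cannot be read: the limit of > 26000 nM in this assay, at which 3 of the 3 values shown sit. The compounds shown leave open at what concentration, if any, these cells respond, and whether 1H-indol-3-yl and furan-2-yl differ at all on this read-out.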